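This account rests on a few compounds, and the source may have more. Where it says the series, first, only, none or still open, it means among the compounds named here.

Compound 1 `CCCCNC(=O)N1Cc2c(NC(=O)c3ccc(C)cc3)nn(C(=O)c3ccccc3)c2C1`: 23200 nM
Compound 2 `CCCCNC(=O)N1Cc2c(NC(=O)c3ccc(F)cc3)nn(C(=O)C3CC3)c2C1`: 23300 nM

These two compounds have been tested in a functional assay on HCT-116 cells (Homo sapiens) for cytotoxicity, read by sulforhodamine B assay, with a stated time of 48 h; on this read-out higher numbers stand for weaker inhibition and lower numbers for stronger inhibition. Compound 2 reads 23300 nM, and compound 1 reads 23200 nM. Within the data shown here, the two numbers lie within the usual scatter of each other, so compound 2 stands level with the only other measured compound, and neither can be ranked above the other.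

The next compound to be tested is compound 3 `CCCCNC(=O)N1Cc2c(NC(=O)c3ccc(F)cc3)nn(C(=O)c3ccccc3)c2C1`. It departs from compound 2 at one place, with phenyl in place of cyclopropyl on a carbonyl carbon, so that cyclopropylcarbonyl becomes benzoyl (phenyl in place of cyclopropyl on a carbonyl carbon). Among the measured compounds shown here, no measured pair of compounds differing in one place is available, so the size of this exchange has not been seen directly in this assay. The expectation therefore rests only on the values of compound 1 at 23200 nM and compound 2 at 23300 nM, and it is for no change beyond the scatter. The expected move is small, in an estimated step of a 1.1-fold lower number from compound 2 to compound 3 (0.05 log units; within the scatter). Compound 3 is estimated at 21000 nM, with an expected range from 9000 nM to 48000 nM.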

Compound 3, half-maximal inhibitory concentration: 30800 nM
Compound 3: the middle estimate sits 1.5-fold (0.17 log units) below what was measured; measured number inside the range.
By their numbers in this assay, from the lowest: compounds 1, 2 and 3 (each within the scatter of the next).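

In this assay, among these compounds, the exchange of cyclopropyl for phenyl on a carbonyl carbon, whose other neighbour is an aromatic nitrogen, can now be read directly for the first time, and it gives a 1.3-fold higher number from compound 2 to compound 3 (0.12 log units; within the scatter), so this position tolerates a three-membered non-aromatic ring and a six-membered aromatic ring alike within the scatter. Among the compounds shown here, the new compound also gives the first direct reading of fluoro in place of methyl on an aromatic carbon, with a 1.3-fold higher number from compound 1 to compound 3 (0.12 log units; within the scatter), so this exchange does not separate the compounds either, and all three remain level in this read-out. Nothing measured alongside these numbers bears on the result, so the steps stand without any explanation.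

From the compounds shown here alone, whether an amine or a carboxylic acid in place of phenyl on that carbonyl carbon, or a methoxy group in place of fluoro on the aromatic carbon, would move the number beyond the scatter remains open. Going by these compounds, all three compounds also carry the same butyl chain on the same core, so the contribution of those parts remains open as well.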